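This account rests on a few compounds, and the source may have more. Where it says the series, first, only, none or still open, it means among the compounds named here.

Three compounds share one core and differ only in the group attached to a carbonyl carbon. Compound 1 `COc1ccc(C(=O)/C=C/c2cc(-c3cc(OC)c(OC)c(OC)c3)n[nH]2)cc1OC` carries a 3,4-dimethoxyphenyl there, and in a functional assay on MDA-MB-231 cells (Homo sapiens) for inhibition, read by MTT assay, with a stated time of 48 h (on this read-out lower numbers stand for stronger inhibition and higher numbers for weaker inhibition), compound 1 gives 620 nM. Compound 2 `COc1cc(-c2cc(/C=C/C(C)=O)[nH]n2)cc(OC)c1OC` carries a methyl in that place, and in this assay compound 2 gives 27300 nM. Compound 3 `COc1cc(-c2cc(/C=C/C(=O)c3ccc(F)c(F)c3)[nH]n2)cc(OC)c1OC` carries a 3,4-difluorophenyl, and in this assay compound 3 gives 1500 nM, the second highest of the three numbers, closer to compound 1 than to compound 2.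

Compound 4 `COc1cc(-c2cc(/C=C/C(=O)c3ccc(Cl)cc3)[nH]n2)cc(OC)c1OC` is the next step from compound 3: 4-chlorophenyl in place of 3,4-difluorophenyl on a carbonyl carbon. Both measured steps that end at compound 3 bear on this. The large step of an 18-fold lower number from compound 2 to compound 3 (1.26 log units; beyond the scatter) shows that an aromatic ring on the carbonyl carbon, set against a methyl, changes the number a great deal, while the modest step of a 2.4-fold higher number from compound 1 to compound 3 (0.38 log units; beyond the scatter) shows that exchanging one substituted phenyl for another moves it far less. The change to compound 4 is again one substituted phenyl for another, so only a small step in this assay is expected, in either direction, quite possibly within the scatter. Compound 4 is therefore estimated at 1200 nM, with a range from 500 nM to 3000 nM, which corresponds to the expected step of a 1.3-fold lower number from compound 3 to compound 4 (0.10 log units; within the scatter).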

Compound 4, half-maximal inhibitory concentration: 26000 nM
Beside the measured number, compound 4's estimate is 22-fold (1.34 log units) below it, outside the stated range (above it).
By their numbers in this assay, from the lowest: compound 1; then compound 3; then compounds 4 and 2 (each within the scatter of the next).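

A ring on the carbonyl carbon is not enough on its own in this assay, since 4-chlorophenyl in place of methyl gives a 1.1-fold lower number from compound 2 to compound 4 (0.02 log units; within the scatter) and so no real difference. What the ring carries matters here too: the exchange of 3,4-difluorophenyl for 4-chlorophenyl gives a 17-fold higher number from compound 3 to compound 4 (1.24 log units; beyond the scatter) and the exchange of 3,4-dimethoxyphenyl for 4-chlorophenyl gives a 42-fold higher number from compound 1 to compound 4 (1.62 log units; beyond the scatter), both large steps, which shows that swapping one substituted phenyl for another at this position can move the number a long way. The small step between compound 1 and compound 3 therefore does not hold for every substituted phenyl, and compound 4 is the one that goes against it.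

The data shown offer no independent measurement that could explain this loss of activity. Compound 4 differs from compound 3 both in its halogen and in the pattern of substitution on the ring, so the compounds shown cannot separate these two changes, a question that 4-fluorophenyl, 3,4-dichlorophenyl or unsubstituted phenyl on the same carbonyl carbon could help to settle.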